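Triazole series: halogen swap on the aryl ring

The source may hold more compounds than are shown below. What is called first, only, known or untested is meant among the compounds shown, and "the series" means these compounds.

Measured compounds and their values:
Compound 1 `FC(F)(F)c1cccc(-n2nncc2-c2ccncc2)c1` gives 68.2 mg/kg in a functional assay on the whole organism with Mus musculus as the target, in the maximal electroshock model; a higher number here means that more compound is needed for the effect, a lower number that less compound is needed.
Compound 2 `Clc1ccc(-n2nncc2-c2cccnc2)cc1` gives 65.8 mg/kg in this assay.
Compound 3 `Clc1ccc(-n2nncc2-c2ccccn2)cc1` gives 95.3 mg/kg in this assay.

Compound 3 has the highest number of the three in this assay, but its gap to compound 1 and its gap to compound 2 both lie within the scatter, so no order among the three is established. Going by the values given here, the only single-point step measured so far, a 1.4-fold higher number from compound 2 to compound 3 (0.16 log units; within the scatter), is also within the scatter.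

Compound 4 `Brc1ccc(-n2nncc2-c2ccccn2)cc1` differs from compound 3 as follows: bromo in place of chloro on an aromatic carbon. Among the compounds with values here, no measured step exchanges one halogen for another on this ring, so nothing among the compounds above bears directly on this change. The shared core and the pyridin-2-yl group are unchanged. Within the data shown here, with no step to lean on and every measured step sitting within the scatter, the expectation for this assay is no shift beyond the scatter, in either direction.

The estimated value for compound 4 is 90 mg/kg, with a range of 45 mg/kg to 180 mg/kg; the expected step is a 1.1-fold lower number from compound 3 to compound 4 (0.02 log units; within the scatter).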

Compound 4, dose for half-maximal effect: 68 mg/kg
Beside the measured number, compound 4's estimate is 1.3-fold (0.12 log units) above it; the measured number falls inside the stated range.
By their numbers in this assay, from the lowest: compounds 2, 4, 1 and 3 (each within the scatter of the next).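

In this assay the halogen on this ring now has a measured exchange: the step is a 1.4-fold lower number from compound 3 to compound 4 (0.15 log units; within the scatter). Going by these compounds alone, with the shared core and the pyridin-2-yl group held fixed, the aromatic carbon para to a large group takes bromo as well as chloro with no shift that can be told from the scatter, so this is the first sign that the series tolerates such an exchange at this position, though it rests on one pair. Nothing measured here bears on the reason for this result.

From the compounds shown here alone, whether an amine, a carboxylic acid or a longer chain at this position would move the number beyond the scatter stays open. Also open, going by these compounds, is whether the same halogen exchange reads alike with pyridin-3-yl in place of pyridin-2-yl.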